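A few compounds are considered here, and "the series" means these few. Any claim that something is new, unique, unknown or untested is made for them only; others in the source may bear on it.

Of the compounds shown here, three sharing one core have been measured in a functional assay; a higher number here means a weaker inhibitor, a lower number a stronger inhibitor. Compound 1 (`CC(C)=CCOc1ccc2c(c1)OC(c1ccc(F)cc1)CC2=O`) gives 7320 nM, compound 2 (`CC(C)=CCOc1ccc2c(c1)OC(c1ccc(C)cc1)CC2=O`) gives 4440 nM, and compound 3 (`CC(C)=CCOc1cc(O)c2c(c1)OC(c1ccc(F)cc1)CC2=O`) gives 6060 nM. Compound 3 thus lies within the scatter of both the others, and the three numbers do not separate.

Compound 4 (`CC(C)=CCOc1cc(O)c2c(c1)OC(c1cccc(Br)c1)CC2=O`) departs from compound 3 in one place: 3-bromophenyl in place of 4-fluorophenyl on a saturated ring carbon. This is 3-bromophenyl in place of 4-fluorophenyl on a saturated ring carbon, next to the ring oxygen.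

Going by the values given here, two measured steps bear on this change. Methyl in place of fluoro on an aromatic carbon gave a 1.6-fold lower number from compound 1 to compound 2 (0.22 log units; within the scatter), the only measured change to the substituent on this aromatic group. Hydroxy in place of hydrogen on an aromatic carbon gave a 1.2-fold lower number from compound 1 to compound 3 (0.08 log units; within the scatter), a change that compound 4 keeps. Among the compounds with values here, neither step left the scatter, but no measured compound carries bromine or a 3-substituted phenyl, so the evidence is thin. No step beyond the scatter is therefore expected in this assay, and the estimated step is a 1.2-fold lower number from compound 3 to compound 4 (0.08 log units; within the scatter). The estimate for compound 4 is 5000 nM, with an expected range from 2000 nM to 12000 nM.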

Compound 4, half-maximal inhibitory concentration: 4040 nM
Estimate against measurement, compound 4: 1.2-fold (0.09 log units) above; measured number inside the range.
By their numbers in this assay, from the lowest: compounds 4, 2, 3 and 1 (each within the scatter of the next).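

In this assay, the change from 4-fluorophenyl to 3-bromophenyl on a saturated ring carbon, next to the ring oxygen, gives a 1.5-fold lower number from compound 3 to compound 4 (0.18 log units; within the scatter), so this position accepts a different halogen, attached at a different place on the phenyl group, without leaving the scatter. Going by these compounds alone, compound 4 is the first compound here to carry bromine or a 3-substituted phenyl, and with a 1.6-fold lower number from compound 1 to compound 2 (0.22 log units; within the scatter) it makes a second change to this aromatic group that stays within the scatter, although the two changes were read with and without the hydroxy group on the shared core. No measurement shown offers an explanation for this result.

Compound 4 changes the halogen and its attachment point together, so the compounds shown cannot separate the two changes; a 4-bromophenyl or a 3-fluorophenyl group would be needed to do that. On these data alone, it also remains open whether a more different substituent on this phenyl group, such as an amine or a carboxylic acid, would produce a step beyond the scatter.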